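Replacing the trichlorophenyl group of compound 3

A few compounds are considered here, and "the series" means these few. Any claim that something is new, unique, unknown or untested is made for them only; others in the source may bear on it.

In a functional assay on DU-145 cells (Homo sapiens) for inhibition, read by trypan blue exclusion, with a stated time of 96 h (on this read-out lower numbers stand for stronger inhibition of growth and higher numbers for weaker inhibition of growth), compound 1 (`COc1ccccc1/C=C(\C(=O)c1ccc(Cl)cc1)S(=O)(=O)Cc1ccc(Cl)c(Cl)c1`) gives 1000 nM and compound 2 (`COc1ccccc1/C=C(\C(=O)c1ccc(Cl)cc1)S(=O)(=O)Cc1ccc(Cl)cc1`) gives 25000 nM. Compound 3 (`Cc1ccc(S/C(=C/c2cc(Cl)cc(Cl)c2Cl)C(=O)c2ccc(Cl)cc2)cc1`) gives 50000 nM, which lies within the scatter of compound 2 and well beyond the scatter of compound 1, whose number is lower.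

Compound 4 (`Cc1ccc(S/C(=C/c2cc(C)cc(C)c2)C(=O)c2ccc(Cl)cc2)cc1`) carries 3,5-dimethylphenyl in place of 2,3,5-trichlorophenyl on a double-bonded chain carbon bound to a double-bonded chain carbon.

Within the data shown here, only one measured step bears on this change, and it also removes chlorine: a 25-fold higher number from compound 1 to compound 2 (1.40 log units; beyond the scatter). This large step, beyond the scatter, puts hydrogen in place of chloro on an aromatic carbon. However, it belongs to a different core and starts from a much lower number, so it is limited guidance here. Among the measured compounds shown here, no measured pair exchanges chloro for methyl. A higher number is possible, but no change beyond the scatter is expected in this assay.

The estimated step is a 1.3-fold lower number from compound 3 to compound 4 (0.10 log units; within the scatter). For compound 4 the estimated value is 40000 nM, with an expected range of 10000 nM to 120000 nM.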

Compound 4, concentration for 50% growth inhibition: 50000 nM
Compound 4: the middle estimate sits 1.3-fold (0.10 log units) below what was measured, and the stated range covers the measured number.
By their numbers in this assay, from the lowest: compound 1; then compounds 2, 3 and 4 (each within the scatter of the next).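

In this assay, among these compounds, the exchange of 2,3,5-trichlorophenyl for 3,5-dimethylphenyl gives no change at the digits printed from compound 3 to compound 4 (within the scatter), the first reading at this place on the double-bonded chain carbon. On the core shared by compound 3 and compound 4, all three chlorine atoms can therefore leave this aromatic ring and two methyl groups can enter without a shift beyond the scatter, unlike the large 25-fold higher number from compound 1 to compound 2 (1.40 log units; beyond the scatter), which removes one chlorine at a different place on another core. Nothing at hand explains why this step stays within the scatter. Still open, as far as these compounds go, is whether a phenyl group carrying an amine or a carboxylic acid at this place would lower the number on this core. Also open, from the compounds shown here alone, is whether 3,5-dimethylphenyl would behave the same way on the core of compound 1.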